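The source may hold more compounds than are shown below. What is called first, only, known or untested is meant among the compounds shown, and "the series" means these compounds.

Working notes on the series.

Compound 1 `ClCc1ccc(Cn2cnc3c(Cl)ncnc32)cc1` is the reference point: in a functional assay on ACHN cells (Homo sapiens) for cytotoxicity, read by sulforhodamine B assay, with a stated time of 48 h (a lower number here means that less compound is tolerated, a higher number that more compound is tolerated), compound 1 gives 3800 nM. Compound 3 `ClCc1ccc(Cn2cnc3c(Cl)nc(Cl)nc32)cc1` carries the change chloro in place of hydrogen on an aromatic carbon relative to compound 1, and in this assay compound 3 gives 14800 nM. That single change produced a 3.9-fold higher number from compound 1 to compound 3 (0.59 log units; beyond the scatter), so within this pair the extra chloro is tolerated less well.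

Compound 2 `ClCc1cccc(Cn2cnc3ncnc(Cl)c32)c1` shares the atoms of compound 1 joined differently; the difference between the two cores is not broken down here. In this assay compound 2 gives 7760 nM, which stands between the other two values, within the scatter of compound 3 and beyond it against compound 1.

Compound 4 `ClCc1cccc(Cn2cnc3nc(Cl)nc(Cl)c32)c1` is not yet measured. It differs from compound 2 by chloro in place of hydrogen on an aromatic carbon, the same change, at a place described in the same words, as that from compound 1 to compound 3. Going by the values given here, the expectation is therefore a step of similar size, a 3.4-fold higher number from compound 2 to compound 4 (0.53 log units; beyond the scatter), resting on the single observed step of a 3.9-fold higher number from compound 1 to compound 3 (0.59 log units; beyond the scatter) and on compound 2 giving 7760 nM. Compound 4 is estimated at 26000 nM, with a plausible range from 10000 nM to 65000 nM.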

Compound 4, concentration lethal to 50% of the cells: 4780 nM
Compound 4: middle estimate off by 5.4-fold (0.74 log units), on the high side; the measured number lies below the stated range.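

Chloro in place of hydrogen on an aromatic carbon gives a 1.6-fold lower number from compound 2 to compound 4 (0.21 log units; within the scatter) in this assay, a step that cannot be told apart from no change. The size of the step therefore does not carry over from one core to the other: the same change on two cores in this assay, a 3.9-fold higher number (0.59 log units; beyond the scatter) from compound 1 to compound 3 and a 1.6-fold lower number (0.21 log units; within the scatter) from compound 2 to compound 4, 6.3-fold (0.80 log units) apart, beyond the scatter of two such steps

This comparison rests on a single pair for each core, so it shows that the result of this change depends on the core within these four compounds, but not which feature of the cores sets the two steps apart or how the change would behave on any further core.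

The compounds shown carry only chloro on the aromatic carbon between two ring nitrogen atoms, so it remains open whether an amine or a methoxy group there would give steps that differ between the two cores in the same way. Also open, on these data alone, is whether the two cores would still differ if a hydroxymethyl group stood in place of the chloromethyl group.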